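Swapping methyl for methoxy on the aryl ring of compound 2

The compounds below may be only part of what the source reports. "The series", "measured", "known", "first", "only" and "open" are said of these compounds alone.

Three compounds share one core and were tested in an assay on HL-60 cells for inhibition of glutathione S-transferase P (Homo sapiens), read by spectrophotometry, tested at 20 uM; a higher number here means more inhibition at the concentration tested (going by the name of the read-out), a lower number less inhibition. Compound 1 `COc1ccc(OC)c(/C=C2\CN(CC(=O)O)c3c(C)cccc3C2=O)c1` gives 5.44% in this assay, compound 2 `Cc1ccc(/C=C2\CN(CC(=O)O)c3c(C)cccc3C2=O)cc1` gives 46.8%, and compound 3 `Cc1ccc(/C=C2\CN(CC(=O)O)c3c(Cl)cccc3C2=O)cc1` gives 67.6%. Compound 2 therefore stands second of the three, with compound 3 beyond the scatter on the higher side and compound 1 beyond the scatter on the lower side. Among the measured compounds shown here, the only single-site step recorded, a number 20.8 percentage points higher from compound 2 to compound 3 (beyond the scatter), concerns the substituent on the core rather than on the pendant aryl ring.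

Compound 4 `COc1ccc(/C=C2\CN(CC(=O)O)c3c(C)cccc3C2=O)cc1` differs from compound 2 as follows: methoxy in place of methyl on an aromatic carbon. For the measured compounds named here, no measured step bears directly on this exchange; compound 1 carries two methoxy groups at other places and differs in more than one way from compound 2, so its low value shows only that heavy methoxy substitution on that ring goes with weak inhibition. Compound 4 is expected to sit somewhat below compound 2, an estimated step of a number 10.8 percentage points lower from compound 2 to compound 4 (beyond the scatter), giving an estimate of 36% with a range from 15% to 58%.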

Compound 4, a percentage reported as inhibition, at one concentration (the size of the read-out at that concentration, not a potency): 31.5%
For compound 4 the middle estimate is 4.5 percentage points above the measured one; the range from low to high includes it.
By their numbers in this assay, from the lowest: compound 1; then compound 4; then compound 2; then compound 3.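

Among the compounds shown here, the change from 4-methylphenyl to 4-methoxyphenyl reads as a number 15.3 percentage points lower from compound 2 to compound 4 (beyond the scatter) in this assay and gives the first single-site reading on the pendant aryl ring, whereas the earlier step concerned the core. It shows that this place, para to a large group, responds to the exchange of one group, methoxy in place of methyl, and that compound 4 keeps part of the inhibition seen for compound 2. Nothing available here gives a reason for this step.

Open, from the compounds shown here alone, is how a hydroxyl, an amine or a longer chain at this same place would compare with methyl and methoxy. Also open, going by these compounds, is whether methoxy in place of methyl would give a step of similar size on compound 3, where chloro replaces methyl on the core.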